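Amine swap on the amide chain: cytotoxicity working notes

The source may report more compounds than this note shows. Statements on the series, on what has been measured and on what is new or still open speak of the compounds shown alone.

Compound 1 `CN(C)C12CC(c3ccccc3)C(CN(C(=O)CCN3CCCCC3)C1)C(c1ccccc1)C2` and compound 2 `CCN(CC)CCC(=O)N1CC2C(c3ccccc3)CC(N(C)C)(CC2c2ccccc2)C1` share one core; compound 3 `CN(C)C12CCN(C(=O)CN3CCCCC3)C(C(c3ccccc3)C1)C(c1ccccc1)C2` and compound 4 `CCN(CC)CC(=O)N1CCC2(N(C)C)CC(c3ccccc3)C1C(c1ccccc1)C2` share another. The difference between the two cores is not broken down here.

In an ADME assay on L6 cells (Rattus norvegicus) for cytotoxicity, read by resazurin assay, with a stated time of 72 h (a lower number here means a stronger inhibitor, a higher number a weaker inhibitor), compound 1 gives 12400 nM. Compound 2 gives 15400 nM in this assay. The change separating these two is diethylamino in place of piperidin-1-yl on a saturated chain carbon, two bonds along the chain from a carbonyl carbon. The measured step is a 1.2-fold higher number from compound 1 to compound 2 (0.09 log units; within the scatter). Among the compounds with values here, compound 3 gives 141000 nM in this assay, the highest of the three numbers so far, well separated from both compound 2 and compound 1.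

Compound 4 stands to compound 3 by the same kind of change: diethylamino in place of piperidin-1-yl on a saturated chain carbon bound to a carbonyl carbon. The place is not identical. In the first pair the change sits on a saturated chain carbon two bonds along the chain from a carbonyl carbon; in compound 4 it sits on a saturated chain carbon bound to a carbonyl carbon, one bond closer.

Within the data shown here, the only measured instance of this kind of change, a 1.2-fold higher number from compound 1 to compound 2 (0.09 log units; within the scatter), falls within the scatter. On that basis the step from compound 3 to compound 4 in this assay is expected to be small, estimated as a 1.1-fold higher number from compound 3 to compound 4 (0.05 log units; within the scatter). Among the measured compounds shown here, the shorter chain and the different core add uncertainty, since no measured pair covers either. Compound 4 is therefore estimated at about 160000 nM in this assay, with an expected range from 70000 nM to 350000 nM.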

Compound 4, half-maximal inhibitory concentration: 89600 nM
For compound 4 the middle estimate is 1.8-fold (0.25 log units) above the measured one; measured number inside the range.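

In this assay, diethylamino in place of piperidin-1-yl on a saturated chain carbon bound to a carbonyl carbon gives a 1.6-fold lower number from compound 3 to compound 4 (0.20 log units; within the scatter), so this step, like the earlier one, stays within the usual scatter. Set side by side, the two steps cannot be told apart: the same change on two cores in this assay, a 1.2-fold higher number (0.09 log units; within the scatter) from compound 1 to compound 2 and a 1.6-fold lower number (0.20 log units; within the scatter) from compound 3 to compound 4, 2.0-fold (0.29 log units) apart, within the scatter of two such steps

In this assay, the change therefore carries between these two cores without a step beyond the scatter on either, but this rests on only two pairs, and the place of the change on the chain differs between them, so the effects of core and chain position cannot be separated, and nothing is shown about any third core or any other assay.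

The compounds shown leave open whether a ring amine such as pyrrolidin-1-yl or morpholin-4-yl, or a non-basic end group such as a carboxylic acid, would read as close to piperidin-1-yl and diethylamino as these two read to each other. They also leave open how either amine would behave on a longer chain on the core of compound 3.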